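Swapping a Side-Chain Group: What Lipophilicity May Follow

The source may hold more compounds than are shown below. What is called first, only, known or untested is meant among the compounds shown, and "the series" means these compounds.

Of the compounds shown here, two have so far been measured in a physicochemical assay for lipophilicity; on this read-out lower numbers stand for lower lipophilicity and higher numbers for higher lipophilicity. Compound 1 `COC(=S)NCCn1c([N+](=O)[O-])cnc1C` gives 0.9, the higher of the two numbers. Compound 2 `Cn1c([N+](=O)[O-])cnc1/C=C(\Oc1ccccc1)C(=O)O` gives -1, a value that lies beyond the usual scatter from that of compound 1; these two compounds differ at several places, so no single change can be read from this gap. Compound 3 `Cc1ncc([N+](=O)[O-])n1CCS(C)(=O)=O` has not yet been measured in this assay. It differs from compound 1 by a group of 4 heavy atoms (1 carbon, 2 oxygen, 1 sulfur; no ring) in place of a group of 5 heavy atoms (2 carbon, 1 nitrogen, 1 oxygen, 1 sulfur; no ring), on a saturated chain carbon, two bonds along the chain from an aromatic nitrogen. Going by the values given here, no measured pair that differs in only one place is available, so the size of this step can only be estimated. The expected step in this assay is a number 1.10 log units lower from compound 1 to compound 3 (beyond the scatter), downward and beyond the usual scatter. Compound 3 is accordingly expected to give about -0.2 in this assay, with a likely range from -0.9 to 0.5.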

Compound 3, partition coefficient: -0.35
Compound 3: the middle estimate sits 0.15 log units above what was measured; low and high end bracket the measured number.
By their numbers in this assay, from the lowest: compound 2; then compound 3; then compound 1.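

Going by these compounds alone, this is the first step in this assay that can be read at one place: on a saturated chain carbon, two bonds along the chain from an aromatic nitrogen, putting methylsulfonyl in place of the group of 5 heavy atoms gives a number 1.25 log units lower from compound 1 to compound 3 (beyond the scatter) and so shows that the read-out responds strongly to what sits at this place. Both groups carry no net charge and no ring and both count 2 hydrogen-bond acceptors, but only the group that leaves has a hydrogen-bond donor. Nothing available explains the size of this step.

A single pair cannot show which part of the exchanged group accounts for the step. As far as these compounds go, how an amine or a methylthio group at this place would read, and whether a longer chain would change the step, remains open.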